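Hydroxy for acetyl on a diaryl-aminothiazole core

A few compounds are considered here, and "the series" means these few. Any claim that something is new, unique, unknown or untested is made for them only; others in the source may bear on it.

Measured compounds:
compound 1 `CC(=O)c1ccc(Nc2nc(-c3ccc(F)cc3)cs2)cc1` — 4900 nM
compound 2 `FC(F)(F)c1ccc(Nc2nc(-c3ccc(Cl)cc3)cs2)cc1` — 5900 nM
compound 3 `Oc1ccc(Nc2nc(-c3ccc(Cl)c(Cl)c3)cs2)cc1` — 900 nM

Of the compounds shown here, three sharing one core have been tested in an assay on isolated protein for inhibition of Polyunsaturated fatty acid 5-lipoxygenase (Homo sapiens), with stated times of 15 min and 10 min; a lower number here means a stronger inhibitor, a higher number a weaker inhibitor. Compound 1 stands second highest of the three numbers. Its nearest neighbour is compound 2, whose value lies within the scatter of compound 1, so no order between the two can be claimed. The furthest is compound 3, whose number is beyond the scatter lower than that of compound 1; compound 3 carries a hydroxy where compound 1 carries an acetyl, and it also differs on the other ring, so the two cannot be compared in one place alone.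

Compound 4 `Oc1ccc(Nc2nc(-c3ccc(F)cc3)cs2)cc1` has not yet been measured. It differs from compound 1 by hydroxy in place of acetyl on an aromatic carbon. Among the measured compounds shown here, no pair of measured compounds differs in this one place, so the size of the step is not known from the data. Still, the hydroxy-bearing compound 3 gives 900 nM, the lowest number shown, which suggests a step downward in this assay. Compound 4 is therefore expected to give 1600 nM, in the range 500 nM to 5000 nM, a step estimated as a 3.1-fold lower number from compound 1 to compound 4 (0.49 log units; beyond the scatter).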

Compound 4, half-maximal inhibitory concentration: 700 nM
The estimate for compound 4 lay 2.3-fold (0.36 log units) above the measured number, and the stated range covers the measured number.
By their numbers in this assay, from the lowest: compounds 4 and 3 (each within the scatter of the next); then compounds 1 and 2 (each within the scatter of the next).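

In this assay, replacing acetyl with hydroxy on an aromatic carbon, para to a large group, now has a measured size: a 7.0-fold lower number from compound 1 to compound 4 (0.85 log units; beyond the scatter), with the rest of the structure unchanged. Until now, hydroxy had appeared only in compound 3, which also differs from compound 1 on the other ring, so the effect of this one change could not be separated from that second difference. Nothing measured here bears on why the number falls with this change.

Among the compounds shown here, this single pair leaves open whether the step would be of similar size with other substituents on the other ring, such as the two chlorines of compound 3 or the single chlorine of compound 2. It also leaves open whether the hydroxy hydrogen matters, which a methoxy group in the same place would test, and how an amine or a carboxylic acid there would compare with hydroxy.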